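One chlorine becomes two on compound 3

The compounds below may be only part of what the source reports. "The series", "measured", "known", "first", "only" and "open" are said of these compounds alone.

In a physicochemical assay for lipophilicity (on this read-out higher numbers stand for higher lipophilicity and lower numbers for lower lipophilicity), compound 1 `C[C@H]1CC[C@@H]2[C@@H](OC(=O)[C@]23CC(c2ccccc2F)=NO3)[C@]2(C)C(=O)C=C[C@@]12O` gives 1.58 and compound 2 `Cc1cccc(C2=NO[C@]3(C2)C(=O)O[C@@H]2[C@H]3CC[C@H](C)[C@]3(O)C=CC(=O)[C@@]23C)c1` gives 1.86. Compound 3 `C[C@H]1CC[C@@H]2[C@@H](OC(=O)[C@]23CC(c2ccc(Cl)cc2)N(c2ccccc2)O3)[C@]2(C)C(=O)C=C[C@@]12O` stands highest of the three at 3.87, beyond the scatter of both others. Compound 4 `C[C@H]1CC[C@@H]2[C@@H](OC(=O)[C@]23CC(c2c(Cl)cccc2Cl)N(c2ccccc2)O3)[C@]2(C)C(=O)C=C[C@@]12O` has 2,6-dichlorophenyl in place of 4-chlorophenyl on a saturated ring carbon, next to the ring nitrogen: 2,6-dichlorophenyl in place of 4-chlorophenyl on a saturated ring carbon. The nearest measured comparison also swaps one substituted phenyl group for another, a number 0.28 log units higher from compound 1 to compound 2 (within the scatter). Going by the values given here, that swap sits on a carbon with a double bond to nitrogen, and no measured step tests a change of chlorine, so it is only a loose guide. The expected change is a modest rise, a number 0.43 log units higher from compound 3 to compound 4 (beyond the scatter). Compound 4 is estimated at 4.3, with an expected range from 3.8 to 4.8.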

Compound 4, partition coefficient: 4.45
Compound 4: middle estimate off by 0.15 log units, on the low side, and the stated range covers the measured number.
By their numbers in this assay, from the lowest: compounds 1 and 2 (each within the scatter of the next); then compound 3; then compound 4.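

Going by these compounds alone, this is the first measured change on the saturated ring carbon next to the ring nitrogen: in this assay, 2,6-dichlorophenyl in place of 4-chlorophenyl gives a number 0.58 log units higher from compound 3 to compound 4 (beyond the scatter) for this step. Within the data shown here, the earlier phenyl swap, on a carbon with a double bond to nitrogen, gave a number 0.28 log units higher from compound 1 to compound 2 (within the scatter) by comparison, so only this step shows a phenyl swap moving the number past the scatter. No measurement here explains the rise. Still open, from the compounds shown here alone, is whether the number of chlorines or their places on the phenyl ring carries the step, and what an amine or a carboxylic acid on that phenyl ring would do.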